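A Leukotriene Receptor Series: From Compound 2 to Compound 4

The source may hold more compounds than are shown below. What is called first, only, known or untested is meant among the compounds shown, and "the series" means these compounds.

Of the compounds shown here, three have been tested in a functional assay on ileum (Cavia porcellus) for inhibition of cysteinyl leukotriene receptor (Homo sapiens); on this read-out higher numbers stand for weaker inhibition and lower numbers for stronger inhibition. Compound 1, `CCCCCc1ccccc1/C=C/C(=O)Nc1cccc2c1OC(c1nnn[nH]1)CO2`, gives 2150 nM. Compound 3, `CCCCCc1ccc(/C=C/C(=O)Nc2cccc3c2OC(C(=O)O)CO3)cc1`, gives 830 nM. Compound 2, `CCCCCc1ccc(/C=C/C(=O)Nc2ccccc2CC(=O)O)cc1`, gives 20000 nM, the highest number of the three, so compound 2 is the weakest inhibitor among them, and its distance to each of the other two lies beyond the usual scatter.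

Compound 4, `CCCCCc1ccc(/C=C/C(=O)Nc2ccccc2OCC(=O)O)cc1`, has not yet been measured. It differs from compound 2 in one place: carboxymethoxy in place of carboxymethyl on an aromatic carbon. Both groups carry the same acid end; the new one is attached to the ring through an oxygen instead of directly through carbon, which lengthens it by one atom. Within the data shown here, no measured pair in this set shows exactly this change, so there is no measured step to lean on; the only guide is that the two measured compounds with a different arrangement of the acid, compound 1 and compound 3, both sit well below compound 2.

Compound 4 is therefore expected to land near compound 2, with a 2.0-fold lower number from compound 2 to compound 4 (0.30 log units; within the scatter) at most a modest step toward stronger inhibition, quite possibly within the scatter. The estimate for compound 4 in this assay is 10000 nM, with a likely range from 3000 nM to 30000 nM.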

Compound 4, half-maximal inhibitory concentration: 9000 nM
The estimate for compound 4 lay 1.1-fold (0.05 log units) above the measured number; the measured number falls inside the stated range.
By their numbers in this assay, from the lowest: compound 3; then compound 1; then compound 4; then compound 2.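

In this assay, replacing carboxymethyl with carboxymethoxy on this aromatic carbon, ortho to a large group, gives a 2.2-fold lower number from compound 2 to compound 4 (0.35 log units; beyond the scatter), a modest step toward stronger inhibition that lies beyond the usual scatter. This shows that the position accepts the larger group, with 5 heavy atoms in place of 4 and an oxygen as its link to the ring, and that inhibition improves rather than being lost. Nothing measured here accounts for the gain, so the step can only be recorded as an observation.

Going by these compounds, it remains open whether the gain depends on the oxygen link itself or simply on the acid end sitting farther from the ring, a question that a carboxyethyl group, an all-carbon chain in the same place, could help to separate. Also unresolved is whether a longer chain, such as carboxypropoxy, would extend the gain or reverse it, and whether moving the carboxymethoxy group to another aromatic carbon of the same ring would keep it.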